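The source may hold more compounds than are shown below. What is called first, only, known or untested is meant among the compounds shown, and "the series" means these compounds.

Compound 2, with the structure `O=C(/C=C/c1ccc(OCc2cn(Cc3cccc(Br)c3)nn2)cc1)c1ccc([N+](=O)[O-])cc1`, gives 21% in a functional assay on MIA PaCa-2 cells (Homo sapiens) for inhibition, read by MTT assay, with a stated time of 48 h, tested at 10 uM (a lower number here means less inhibition of growth, a higher number more inhibition of growth at the concentration tested), the lower of the two measured numbers. Compound 1, `COc1ccc(C(=O)/C=C/c2ccc(OCc3cn(Cc4ccc(Br)cc4)nn3)cc2)cc1`, gives 56% in this assay, a gap beyond the usual scatter, though the two differ in more than one place. Compound 3, `O=C(/C=C/c1ccc(OCc2cn(Cc3ccc(Br)cc3)nn2)cc1)c1ccc([N+](=O)[O-])cc1`, is related to compound 2 by 4-bromophenyl in place of 3-bromophenyl on a saturated chain carbon bound to an aromatic nitrogen, bringing in the 4-bromobenzyl that compound 1 also carries. The step from compound 2 to compound 3 is expected to be small, at most a modest gain, and a number 9 percentage points higher from compound 2 to compound 3 (within the scatter) states this expectation. Compound 3 is estimated at 30%, with a range from 12% to 55%.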

Compound 3, percent growth inhibition at one concentration: 17%
Estimate against measurement, compound 3: 13 percentage points above, within the range that was stated.
By their numbers in this assay, from the lowest: compounds 3 and 2 (each within the scatter of the next); then compound 1.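

Exchanging 3-bromophenyl for 4-bromophenyl on a saturated chain carbon bound to an aromatic nitrogen gives a number 4 percentage points lower from compound 2 to compound 3 (within the scatter) in this assay, so this change leaves no readable shift. With the 4-bromobenzyl shared, nitro in place of methoxy on an aromatic carbon gives a number 39 percentage points lower from compound 1 to compound 3 (beyond the scatter), which places the earlier gap on that substituent, not on the bromophenyl change. Nothing available explains this drop. Still open, on these data alone, is whether other groups on that aromatic carbon, such as an amine or a carboxylic acid, would match compound 1 or compound 3.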